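This account rests on a few compounds, and the source may have more. Where it says the series, first, only, none or still open, it means among the compounds named here.

Compound 1 `Cc1ccc(N2CCN(C(=O)c3oc(C)nc3-c3ccccc3)CC2)cc1` is tested in a functional assay on HL-60 cells (Homo sapiens) for inhibition, read by MTT assay, with a stated time of 72 h; on this read-out lower numbers stand for stronger inhibition and higher numbers for weaker inhibition. In this assay compound 1 gives > 1000 nM, which is a limit of the assay rather than a number. Two related compounds carry numbers. Compound 2 `Cc1ccc(C)c(N2CCN(C(=O)c3oc(C)nc3-c3ccc(F)cc3)CC2)c1` gives 358 nM in this assay, and compound 3 `CCc1nc(-c2ccccc2Cl)c(C(=O)N2CCN(c3cccc(Cl)c3)CC2)o1` gives 98.9 nM in this assay. Compound 1 thus stands at the weak end of what has been measured, with one of the three results sitting at the limit (the limit of > 1000 nM in this assay, at which 1 of the 3 values shown sits).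

Compound 4 `Cc1nc(-c2ccccc2)c(C(=O)N2CCN(c3ccccc3F)CC2)o1` has not yet been measured in this assay. It differs from compound 1 in one place: 2-fluorophenyl in place of 4-methylphenyl on an amine nitrogen in a ring. Going by the values given here, compound 2 and compound 3 are not single-step neighbours of either compound, so they show only that halogenated aryl groups on this shared core have given measurable numbers, without fixing the size of this particular change.

For the step from compound 1 to compound 4 the account expects a modest gain in this assay, an at least 1.2-fold lower number from compound 1 to compound 4 (0.09 log units; that floor lies within the scatter), though it may fall within the scatter of repeated measurements. Compound 4 is therefore estimated at 800 nM, with a range from 250 nM to 3000 nM.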

Compound 4, half-maximal inhibitory concentration: 147 nM
The estimate for compound 4 lay 5.4-fold (0.74 log units) above the measured number; measured number below the stated range.
By their numbers in this assay, from the lowest: compounds 3 and 4 (each within the scatter of the next); then compound 2. At a limit, above all of these: compound 1.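

Replacing 4-methylphenyl with 2-fluorophenyl on the amine nitrogen in the ring gives, in this assay, an at least 6.8-fold lower number from compound 1 to compound 4 (0.83 log units; beyond the scatter). Going by these compounds alone, this is the first comparison here in which only one place changes, so it shows that the group on this nitrogen can by itself move the read-out beyond the scatter, which compound 2 and compound 3 could only hint at. The step is a floor rather than a measured size because compound 1 stands at a limit of the assay and has no number: the limit of > 1000 nM in this assay, at which 1 of the 4 values shown sits.

The compounds shown do not separate the part played by adding the fluorine from the part played by losing the methyl, since an unsubstituted phenyl or a 4-fluorophenyl on this nitrogen does not appear among them. They also leave open how a 2-methoxyphenyl, a pyridyl ring or a saturated cyclohexyl group would read at this position, and whether the step would carry over to the other substituents on the shared core.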